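This account rests on a few compounds, and the source may have more. Where it says the series, first, only, none or still open, it means among the compounds named here.

Measured compounds in the series:
- compound 1, `O=C(N/N=C/c1ccc(O)cc1)c1cccnc1Nc1cccc(C(F)(F)F)c1`: 61.6%
- compound 2, `COc1cccc(/C=N/NC(=O)c2cccnc2Nc2cccc(C(F)(F)F)c2)c1`: 14.9%

In a functional assay on the whole organism (strain Wistar) for inhibition, with Rattus norvegicus as the target, read by paw edema, with a stated time of 4 h, at a dose of 10 mg/kg by the intraperitoneal route (a lower number here means less inhibition, a higher number more inhibition at the dose given (going by the name of the read-out)), compound 1 gives 61.6% and compound 2 gives 14.9%. Among the compounds with values here, compound 2 stands lowest of the two numbers; its nearest neighbour is compound 1, and the single step between them, a number 46.7 percentage points lower from compound 1 to compound 2 (beyond the scatter), is large and beyond the scatter. That step changes both the group and its position on the ring at once, so it does not separate the two effects.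

Compound 3, `COc1ccc(/C=N/NC(=O)c2cccnc2Nc2cccc(C(F)(F)F)c2)cc1`, is not yet measured. It differs from compound 2 by 4-methoxyphenyl in place of 3-methoxyphenyl on a carbon with a double bond to nitrogen, so it carries the methoxy group at the ring position that compound 1 occupies with its hydroxyl. Within the data shown here, only the step from compound 1 to compound 2 bears on this change, and it bears only indirectly: it shows that moving from compound 1 to the arrangement of compound 2 lost a great deal, but whether the position or the group drove the loss is not known from these two values. Compound 3 is therefore expected to lie between the two measured values, with a step of a number 20.1 percentage points higher from compound 2 to compound 3 (beyond the scatter) upward from compound 2, and a wide uncertainty. The estimate for compound 3 in this assay is 35%, with a range from 10% to 60%.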

Compound 3, a percentage reported as inhibition, in the whole organism at one dose (the size of the read-out at that dose, not a potency): 14%
Beside the measured number, compound 3's estimate is 21 percentage points above it; the range from low to high includes it.
By their numbers in this assay, from the lowest: compounds 3 and 2 (each within the scatter of the next); then compound 1.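

Within this assay, the ring position of the methoxy group makes no difference that can be read: a number 0.9 percentage points lower from compound 2 to compound 3 (within the scatter), so 3-methoxyphenyl and 4-methoxyphenyl on a carbon with a double bond to nitrogen cannot be told apart here. Within the data shown here, the earlier pair changed group and position together, whereas the single change of methyl in place of hydrogen on the aromatic oxygen gives a number 47.6 percentage points lower from compound 1 to compound 3 (beyond the scatter), which locates a large loss at the capping of the hydroxyl, with the ring position held fixed. No measurement in hand bears on why this capping goes with the loss.

Still open, from the compounds shown here alone, is whether the hydroxyl keeps the level of compound 1 when it stands at the ring position that compound 2 uses for its methoxy group, since the insensitivity to position is seen only for the methoxy pair. Also open, going by these compounds, is whether other groups in the place of that hydroxyl, such as an amine or a carboxylic acid, or a longer chain such as ethyl on the oxygen, would retain inhibition or fall with the methoxy compounds.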